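Cytotoxicity notes on azido nucleoside analogues

This account rests on a few compounds, and the source may have more. Where it says the series, first, only, none or still open, it means among the compounds named here.

Measured compounds:
- compound 1, `COC(=O)[C@H]1O[C@@H](n2cc(C)c(=O)[nH]c2=O)C[C@@H]1N=[N+]=[N-]`: in an ADME assay on Huh-7 cells (Homo sapiens) for cytotoxicity, read by XTT assay, with a stated time of 2 days (on this read-out higher numbers stand for lower toxicity in this test and lower numbers for higher toxicity in this test), compound 1 gives > 847000 nM.
- compound 2, `Cc1cn([C@H]2C[C@H](N=[N+]=[N-])[C@@H](C(N)=O)O2)c(=O)[nH]c1=O`: in this assay compound 2 gives > 893000 nM.

Compound 2 stands at a limit of this assay, (the limit of > 893000 nM in this assay, at which 1 of the 2 values shown sits); no number is measured for it. Compound 1 likewise stands at a limit, (the limit of > 847000 nM in this assay, at which 1 of the 2 values shown sits). Among the compounds with values here, the single measured step, a step that the two limits leave unreadable from compound 1 to compound 2, therefore cannot be sized, as both ends are limits.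

The next compound, compound 3, `[N-]=[N+]=N[C@H]1C[C@H](n2ccc(=O)[nH]c2=O)O[C@@H]1C(N)=O`, differs from compound 2 by hydrogen in place of methyl on an aromatic carbon. Within the data shown here, no measured step covers a change of this kind, and the only step recorded is unreadable. Both measured compounds reach the top of the tested range without a readable value (the limit of > 847000 nM in this assay, at which 1 of the 2 values shown sits, (the limit of > 893000 nM in this assay, at which 1 of the 2 values shown sits)), so the expectation for compound 3 is that it too reports only a limit in this assay, with a step that the limit leaves unreadable from compound 2 to compound 3 expected to stay within the scatter. Compound 3 is estimated at 900000 nM, with a range from 300000 nM to 3000000 nM.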

Compound 3, half-maximal cytotoxic concentration: > 940000 nM
Compound 3: a limit, no number (the forecaster's own chance of this, stated with the estimate: 85%); at least 1.0-fold (0.01 log units) between middle value and limit.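

In this assay compound 3 gives > 940000 nM, a limit and not a number. Compound 2 also stands at a limit, > 893000 nM, so the step between compound 2 and compound 3 cannot be read. The compounds shown leave open whether any change to the shared core would give a readable value in this assay.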